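The source may report more compounds than this note shows. Statements on the series, on what has been measured and on what is new or still open speak of the compounds shown alone.

Measured so far:

Compound 1 `COc1ccc(/C=C/C(=O)/C=C/c2cc3ccccc3nc2Oc2ccc(Br)cc2)c(OC)c1` — in a functional assay on 4T1 cells (Mus musculus) for cytotoxicity, read by MTT assay, with a stated time of 48 h (a lower number here means a stronger inhibitor, a higher number a weaker inhibitor), compound 1 gives > 10000 nM, a limit of the assay rather than a number.
Compound 2 `COc1ccc(OC)c(/C=C/C(=O)/C=C/c2cc3ccccc3nc2Oc2ccc(Br)cc2)c1` — in this assay compound 2 gives > 10000 nM, again a limit and not a number.
Compound 3 `COc1ccc(/C=C/C(=O)/C=C/c2cc3ccccc3nc2Oc2cccc(Cl)c2)c(OC)c1` — in this assay compound 3 gives > 10000 nM, once more a limit only.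

The change from compound 1 to compound 2 is 2,5-dimethoxyphenyl in place of 2,4-dimethoxyphenyl on a double-bonded chain carbon bound to a double-bonded chain carbon. The step it made in this assay is a step that the two limits leave unreadable from compound 1 to compound 2, and its size cannot be read because the limit of > 10000 nM in this assay, at which 3 of the 3 values shown sit, holds both ends of the pair. The cores of compound 1 and compound 3 differ by 3-chlorophenyl in place of 4-bromophenyl on an oxygen on an aromatic ring; the step between them in this assay is a step that the two limits leave unreadable from compound 1 to compound 3, and it too is hidden by the same limit.

Compound 4 `COc1ccc(OC)c(/C=C/C(=O)/C=C/c2cc3ccccc3nc2Oc2cccc(Cl)c2)c1` has not yet been measured in this assay. It differs from compound 3 by 2,5-dimethoxyphenyl in place of 2,4-dimethoxyphenyl on a double-bonded chain carbon bound to a double-bonded chain carbon, and since the place is worded the same as for the change from compound 1 to compound 2, this is the same change made a second time. The first time it ran between two limits, so the expected step from compound 3 to compound 4 in this assay is a step that the limit leaves unreadable from compound 3 to compound 4, and this expectation rests on compound 3 sitting at > 10000 nM together with the unreadable step that the two limits leave unreadable from compound 1 to compound 2. Compound 4 is therefore expected to give about 20000 nM in this assay, most likely reported once again as a limit, with an estimated range from 8000 nM to 60000 nM.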

Compound 4, half-maximal inhibitory concentration: > 10000 nM
Compound 4: a limit, no number; the forecaster's own chance of this, stated with the estimate: 85%; the middle value does not contradict the limit.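

In this assay compound 4 gives > 10000 nM as a limit and not a number. Among the compounds shown here, no step from compound 3 or compound 2 to compound 4 can be read, because every compound sits at the same limit: the limit of > 10000 nM in this assay, at which 4 of the 4 values shown sit.

The compounds shown leave open whether 2,5-dimethoxyphenyl in place of 2,4-dimethoxyphenyl, or 3-chlorophenyl in place of 4-bromophenyl, changes the cytotoxicity at all.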